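A few compounds are considered here, and "the series" means these few. Any claim that something is new, unique, unknown or untested is made for them only; others in the source may bear on it.

Measured so far:
compound 1 `Cc1cnnc(C#Cc2ccccc2)n1` — in a functional assay on CHO-K1 cells for antagonist activity at metabotropic glutamate receptor 5 (Homo sapiens), read by calcium flux (on this read-out higher numbers stand for weaker inhibition and lower numbers for stronger inhibition), compound 1 gives 140 nM
compound 2 `COc1cccc(C#Cc2nncc(C)n2)c1` — in this assay compound 2 gives 312 nM

Among the measured compounds shown here, compound 2 stands highest of these two numbers; its nearest neighbour is compound 1, and the single measured step, a 2.2-fold higher number from compound 1 to compound 2 (0.35 log units; beyond the scatter), is modest. Compound 3 `Cc1cnnc(C#Cc2cccc(C#N)c2)n1` differs from compound 2 by cyano in place of methoxy on an aromatic carbon. For the measured compounds named here, no measured step exchanges methoxy for cyano, so the one step bears on compound 3 only by showing that a change at this carbon moved the number modestly. Compound 3 is therefore expected to show a step of a 2.1-fold lower number from compound 2 to compound 3 (0.32 log units; beyond the scatter), staying close to the scatter. The estimate for compound 3 is 150 nM, with a range from 50 nM to 450 nM.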

Compound 3, half-maximal inhibitory concentration: 52 nM
For compound 3 the middle estimate is 2.9-fold (0.46 log units) above the measured one; the range from low to high includes it.
By their numbers in this assay, from the lowest: compound 3; then compound 1; then compound 2.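

In this assay, cyano at this aromatic carbon moves the number the opposite way from methoxy, giving a 2.7-fold lower number from compound 1 to compound 3 (0.43 log units; beyond the scatter) and a 6.0-fold lower number from compound 2 to compound 3 (0.78 log units; beyond the scatter) as well. The direction of the step at this carbon therefore depends on the group placed there, and compound 3 shows the strongest inhibition of the three, with its steps to both others printed as beyond the scatter. No evidence is available on why these two groups part in this way.

Going by these compounds, whether an amine or a carboxylic acid at this carbon would lower the number as cyano does or raise it as methoxy does stays open. So does whether cyano would give a similar step on another carbon of the ring.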